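From naphthalen-2-yl to 4-iodophenyl on a shared core

The source may hold more compounds than are shown below. What is called first, only, known or untested is meant among the compounds shown, and "the series" means these compounds.

Of the compounds shown here, two have so far been tested in an ADME assay on BJ cells (Homo sapiens) for cytotoxicity, with a stated time of 72 h; a lower number here means that less compound is needed, a higher number that more compound is needed for the effect. Compound 1 `COc1ccc(-c2nc3c(c(C)nn3-c3ccccc3)c(-c3ccccc3O)c2C#N)cc1` gives > 23000 nM, which is a limit of the assay. Compound 2 `Cc1nn(-c2ccccc2)c2nc(-c3ccc4ccccc4c3)c(C#N)c(-c3ccccc3O)c12` gives > 20000 nM, which is also a limit. Compound 2 therefore has no exact number, and the only other result beside it is a limit too.

Compound 3 `Cc1nn(-c2ccccc2)c2nc(-c3ccc(I)cc3)c(C#N)c(-c3ccccc3O)c12` differs from compound 2 in one place: 4-iodophenyl in place of naphthalen-2-yl on an aromatic carbon. The 4-iodophenyl group sits on an aromatic carbon, next to the ring nitrogen and ortho to a cyano group.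

Within the data shown here, one measured step bears on this change: a step that the two limits leave unreadable from compound 1 to compound 2, with naphthalen-2-yl in place of 4-methoxyphenyl. Its size cannot be read, since both of its ends are limits. It offers no sign of a large effect from this group, so no step beyond the usual scatter is expected in this assay, and another limit is the likeliest result. The expected change is a step that the limit leaves unreadable from compound 2 to compound 3. For compound 3 the estimate is 22000 nM, with an expected range from 9000 nM to 45000 nM.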

Compound 3, half-maximal effective concentration: 19000 nM
Beside the measured number, compound 3's estimate is 1.2-fold (0.06 log units) above it; the range from low to high includes it.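

In this assay compound 3 is the only one of the three shown with an exact number, so the 4-iodophenyl group, on an aromatic carbon next to the ring nitrogen and ortho to a cyano group, gives this position its one readable value. Putting 4-iodophenyl, with one aromatic ring, in place of naphthalen-2-yl, with two, gives an at least 1.0-fold lower number from compound 2 to compound 3 (0.02 log units; that floor lies within the scatter), and iodo in place of methoxy gives an at least 1.2-fold lower number from compound 1 to compound 3 (0.08 log units; that floor lies within the scatter), so neither change shows a shift beyond the scatter, although the real size of each could be greater. The step from compound 1 to compound 2 still cannot be read, and both new steps rest on limits of the assay rather than on numbers, so they give only floors.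

From the compounds shown here alone, how far the true numbers of compound 1 and compound 2 lie from that of compound 3 stays open. Equally open is how this assay responds when this position carries an amine or a carboxylic acid, whereas all three compounds shown hold an aromatic carbon ring there.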